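Amide variation in a cytotoxicity series, one step ahead

The compounds below may be only part of what the source reports. "The series", "measured", "known", "first", "only" and "open" are said of these compounds alone.

compound 1 `CCCN(C)C(=O)c1ccc(-c2cc(-c3cc(OC)ccc3OC)no2)s1` — in a functional assay on PC-3 cells (Homo sapiens) for cytotoxicity, read by XTT assay, with a stated time of 72 h (on this read-out lower numbers stand for stronger inhibition and higher numbers for weaker inhibition), a limit, > 30000 nM
compound 2 `COc1ccc(OC)c(-c2cc(-c3ccc(C(=O)N(C)C)s3)on2)c1` — in this assay a limit, > 30000 nM

In this assay compound 1 gives only a limit, > 30000 nM. In this assay compound 2 likewise gives only a limit, > 30000 nM. The step that the two limits leave unreadable from compound 1 to compound 2 is accordingly unreadable, since both values sit at the limit of > 30000 nM in this assay, at which 2 of the 2 values shown sit. Compound 2 therefore stands at the assay limit, with no number of its own.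

Compound 3 `COc1ccc(OC)c(-c2cc(-c3ccc(C(=O)NCC4CC4)s3)on2)c1` differs from compound 2 by (cyclopropylmethyl)amino in place of dimethylamino on a carbonyl carbon. Among the compounds with values here, no measured step bears on this change; the only step known is unreadable. Another limit is expected. The estimate for compound 3 is 30000 nM, with a range from 10000 nM to 100000 nM. The expected step is a number no higher from compound 2 to compound 3 (the limit leaves the size open).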

Compound 3, half-maximal inhibitory concentration: > 30000 nM
Compound 3: no number, only a limit; the forecaster's own chance of this, stated with the estimate: 75%; the middle value lies on the limit itself.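

Within the data shown here, no step among compound 1, compound 2 and compound 3 can be read in this assay, since all three give only a limit: the limit of > 30000 nM in this assay, at which 3 of the 3 values shown sit. Which amide on the shared core, if any, gives a measurable number in this assay remains open.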